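Cytotoxicity of a Trifluoromethyl Analogue, Expected Limit

The source may report more compounds than this note shows. Statements on the series, on what has been measured and on what is new or still open speak of the compounds shown alone.

Compound 1, `COc1cc(/C=C/c2nc(NC3CC3)c3sccc3n2)cc(OC)c1OC`, in an ADME assay on RAW264.7 cells (Mus musculus) for cytotoxicity, read by MTT assay; a higher number here means a weaker inhibitor, a lower number a stronger inhibitor: > 50000 nM, a limit of the assay.
Compound 2, `COc1ccc(Nc2nc(/C=C/c3cc(OC)c(OC)c(OC)c3)nc3ccsc23)cc1`, in this assay: > 50000 nM, a limit of the assay.
Compound 3, `COc1cc(/C=C/c2nc(Nc3ccc(C(F)(F)F)cc3)c3sccc3n2)cc(OC)c1OC`, not yet measured in this assay.

Compound 2 stands at a limit in this assay and shows no number of its own. Going by the values given here, the single measured step, a step that the two limits leave unreadable from compound 1 to compound 2, is unreadable, since both of its ends sit at the limit of > 50000 nM in this assay, at which 2 of the 2 values shown sit.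

The change to compound 3 is trifluoromethyl in place of methoxy on an aromatic carbon. Among the compounds with values here, no measured step bears directly on this change; the only step available, the one from compound 1 to compound 2, alters a different part of the molecule and yields no readable size. What remains is the observation that both measured compounds sit at the limit of > 50000 nM in this assay, at which 2 of the 2 values shown sit, which gives no sign of any cytotoxicity within the tested range.

The step from compound 2 to compound 3 in this assay is therefore expected to be a number no higher from compound 2 to compound 3 (the limit leaves the size open), that is, none beyond the scatter. Compound 3 is expected to give about 50000 nM in this assay, between 20000 nM and 150000 nM, and most likely to be reported again only as a limit.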

Compound 3, half-maximal inhibitory concentration: > 50000 nM
Compound 3: only a limit was reported; the forecaster's own chance of this, stated with the estimate: 75%; the middle value sits exactly at the limit.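

Going by these compounds alone, no step among compound 1, compound 2 and compound 3 can be read in this assay, because each result is a limit of the assay and not a number: the limit of > 50000 nM in this assay, at which 3 of the 3 values shown sit.

The compounds shown leave open whether exchanging cyclopropyl, 4-methoxyphenyl and 4-(trifluoromethyl)phenyl on the shared core changes cytotoxicity at all, and at what concentration any of the three would show it.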